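Fixing a Stereocentre in a Triazole-Linked Quinone Series

This account rests on a few compounds, and the source may have more. Where it says the series, first, only, none or still open, it means among the compounds named here.

Measured compounds:
Compound 1, `CC1(C)O[C@@H](CO)[C@H](Cn2cc(Cn3c4c(c5ccccc53)C(=O)c3c[n+]([O-])c5ccccc5c3C4=O)nn2)O1`: 500 nM
Compound 2, `O=C1c2c[n+]([O-])c3ccccc3c2C(=O)c2[nH]c3ccccc3c21`: 400 nM
Compound 3, `CC1(C)OCC(Cn2cc(Cn3c4c(c5ccccc53)C(=O)c3c[n+]([O-])c5ccccc5c3C4=O)nn2)O1`: 120 nM

Three compounds carry a number in a toxicity assay on L02 cells (Homo sapiens) for cytotoxicity, read by MTT assay, with a stated time of 72 h; on this read-out lower numbers stand for stronger inhibition and higher numbers for weaker inhibition. Compound 1, which bears the 5-(hydroxymethyl)-2,2-dimethyl-1,3-dioxolan-4-yl group, gives 500 nM; compound 2, the bare core, gives 400 nM; compound 3 gives 120 nM. Compound 3 stands lowest of the three, with both other compounds beyond the scatter above it. Within the data shown here, the only single-point step measured is a 4.2-fold lower number from compound 1 to compound 3 (0.62 log units; beyond the scatter), which exchanges one dioxolane substituent for another.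

Compound 4, `CC1(C)OC[C@@H](Cn2cc(Cn3c4c(c5ccccc53)C(=O)c3c[n+]([O-])c5ccccc5c3C4=O)nn2)O1`, is the next step. The difference from compound 3 is the two compounds have the same atoms and bonds; at least one stereo element is drawn with a configuration in one of them and without one in the other: 1 of 1 stereo elements differ; a stereocentre at a saturated ring carbon is drawn without a configuration in compound 3 and R in compound 4. Among the measured compounds shown here, no measured pair shows what fixing a stereocentre does here; the step from compound 1 to compound 3 concerns a change of substituent, not configuration, so it does not bear directly on this change. With the same atoms and bonds, the expectation is that compound 4 stays close to compound 3, allowing that a single configuration could separate from the mixture in either direction. Compound 4 is therefore expected to give 110 nM, within 45 nM to 280 nM. That corresponds to an expected step of a 1.1-fold lower number from compound 3 to compound 4 (0.04 log units; within the scatter).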

Compound 4, half-maximal inhibitory concentration: 2900 nM
Beside the measured number, compound 4's estimate is 26-fold (1.42 log units) below it; the whole stated range lies below it.
By their numbers in this assay, from the lowest: compound 3; then compounds 2 and 1 (each within the scatter of the next); then compound 4.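

In this assay, the drawn configuration at this saturated ring carbon of the 2,2-dimethyl-1,3-dioxolan-4-yl group turns out to matter a great deal, with a 24-fold higher number from compound 3 to compound 4 (1.38 log units; beyond the scatter), the largest step in the set. It also changes how the earlier substituent exchange reads: losing the hydroxymethyl went with a lower number in the step to compound 3, but the same exchange now gives a 5.8-fold higher number from compound 1 to compound 4 (0.76 log units; beyond the scatter), so the direction of that exchange depends on which of the two dioxolane compounds is taken, and compound 4 goes against the trend suggested by compound 3. The large gap between compound 3 and compound 4 can be traced to a single structural difference, since nothing else separates them: the fact that one of compounds 3 and 4 is drawn with a defined configuration and the other without, at the place where they differ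

The compounds shown leave open how the S configuration at this carbon would read, and so which stereo form, if either, accounts for the low number of compound 3. They also leave open whether the sensitivity to configuration would persist if a primary amine or a carboxylic acid replaced the dioxolane on the saturated chain carbon bound to an aromatic nitrogen.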